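Series notes: amide and sulfonamide variants on a shared core

The source may hold more compounds than are shown below. What is called first, only, known or untested is meant among the compounds shown, and "the series" means these compounds.

Measured so far:
compound 1, `CC(=O)N(C)c1ccc2[nH]c(-c3n[nH]c4ccccc34)cc2n1`, 14800 nM
compound 2, `COc1ccc(S(=O)(=O)N(C)c2ccc3[nH]c(-c4n[nH]c5ccccc45)cc3n2)cc1`, 22400 nM
compound 3, `COc1ccc(OC)c(S(=O)(=O)N(C)c2ccc3[nH]c(-c4n[nH]c5ccccc45)cc3n2)c1`, 8400 nM

In a functional assay on HCT-116 cells (Homo sapiens) for antiproliferative activity, read by MTT assay, with a stated time of 72 h (a higher number here means a weaker inhibitor, a lower number a stronger inhibitor), compound 1 stands second highest of the three numbers; compound 2 sits within the scatter of it, and compound 3 is within the scatter on the other side, so no order among the three can be read, apart from a 2.7-fold lower number from compound 2 to compound 3 (0.43 log units; beyond the scatter), a modest step that lies beyond the scatter.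

The next compound is compound 4, `COc1ccc(NC(=O)N(C)c2ccc3[nH]c(-c4n[nH]c5ccccc45)cc3n2)cc1`, which differs from compound 1 as follows: (4-methoxyphenyl)amino in place of methyl on a carbonyl carbon. For the measured compounds named here, no measured step covers this change on the carbonyl carbon. Going by the values given here, the only pair that touches the (4-methoxyphenyl) group is compound 1 against compound 2, where a small acetyl and a 4-methoxyphenyl sulfonyl group give values within the scatter of each other; this weakly suggests the entering group is tolerated without a large shift. The step to compound 3 is on the sulfonyl side and does not bear on compound 4.

Accordingly, compound 4 is expected to show a 1.2-fold lower number from compound 1 to compound 4 (0.09 log units; within the scatter), a step within the scatter. The estimate for compound 4 is 12000 nM, with a range of 4000 nM to 40000 nM.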

Compound 4, half-maximal inhibitory concentration: 63 nM
Compound 4: the middle estimate sits 190-fold (2.28 log units) above what was measured, and the stated range ends above it.
By their numbers in this assay, from the lowest: compound 4; then compounds 3, 1 and 2 (each within the scatter of the next, the first and the last beyond it).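

In this assay the carbonyl carbon proves highly sensitive to what it carries: (4-methoxyphenyl)amino in place of methyl gives a 230-fold lower number from compound 1 to compound 4 (2.37 log units; beyond the scatter) and so far outstrips the modest 2.7-fold lower number from compound 2 to compound 3 (0.43 log units; beyond the scatter) on the sulfonyl side. This single change brings in an aromatic ring, a hydrogen-bond donor and a hydrogen-bond acceptor together, so the step belongs to the entering group as a whole and not to any one of its parts. No available data account for the size of this step.

Which part of the group carries the step stays open, whether the amino hydrogen, the ring or the methoxy. Also open, on these data alone, is how phenylamino, methylamino or benzylamino would compare on the same carbonyl carbon.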